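The source may report more compounds than this note shows. Statements on the series, on what has been measured and on what is new or still open speak of the compounds shown alone.

In a functional assay on MDA-MB-468 cells (Homo sapiens) for antiproliferative activity, read by sulforhodamine B assay, with a stated time of 4 days (a lower number here means a stronger inhibitor of growth, a higher number a weaker inhibitor of growth), compound 3 `COc1cc(Cl)c(-c2nc(SCC(=O)NC(C)(C)C)nc3[nH]cc(C#N)c23)cc1OC` gives 84 nM. Compound 2 `COc1cc(Cl)c(-c2nc(SCC(=O)NC(C)(C)C)nc3[nH]cc(C#N)c23)cc1O` gives 152 nM, within the scatter of compound 3, while compound 1 `CCOc1cc(-c2nc(SCC(=O)NC3CC3)nc3[nH]cc(C#N)c23)c(Cl)cc1OC` gives 23 nM, a clearly lower number.

Compound 4 `CNC(=O)CSc1nc(-c2cc(OC)c(OC)cc2Cl)c2c(C#N)c[nH]c2n1` departs from compound 3 in one place: methyl in place of tert-butyl on an amide-type nitrogen.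

Among the measured compounds shown here, the only measured step, a 1.8-fold lower number from compound 2 to compound 3 (0.26 log units; within the scatter), is a methyl in place of hydrogen on an oxygen on an aromatic ring. For the measured compounds named here, that is a different place, so it gives no direct guide, and no measured step isolates the group on the amide-type nitrogen. Compound 1, at 23 nM, has no tert-butyl there, but it also differs from compound 3 elsewhere, so it supports only a weak lean towards a lower number in this assay.

No change beyond the scatter is therefore expected, and the expected step is a 1.4-fold lower number from compound 3 to compound 4 (0.15 log units; within the scatter). For compound 4 the estimate is 60 nM, with an expected range of 20 nM to 200 nM.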

Compound 4, concentration for 50% growth inhibition: 33 nM
Compound 4: the middle estimate sits 1.8-fold (0.26 log units) above what was measured, within the range that was stated.
By their numbers in this assay, from the lowest: compounds 1 and 4 (each within the scatter of the next); then compounds 3 and 2 (each within the scatter of the next).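

In this assay, among the compounds shown here, the change of tert-butyl to methyl on the amide-type nitrogen gives a 2.5-fold lower number from compound 3 to compound 4 (0.41 log units; beyond the scatter), a modest step but one beyond the scatter, and the first measured change at this position. It shows that tert-butyl is not needed here for growth inhibition on this core: methyl, with 1 heavy atom in place of 4, gives the lower number. Nothing measured here explains why the number falls with this change.

The compounds shown leave open how the number moves between these two groups, or with only the amide hydrogen, as no ethyl or isopropyl group stands at this nitrogen on the same core. Going by these compounds, compound 1 carries cyclopropyl there but differs elsewhere too, and it remains open how a longer chain ending in an amine or a carboxylic acid would behave.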